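This account rests on a few compounds, and the source may have more. Where it says the series, first, only, none or still open, it means among the compounds named here.

The measured compounds in a functional assay on SW-620 cells (Homo sapiens) for cytotoxicity, read by MTT assay, with stated times of 4 h and 72 h, tested at 2 uM; a higher number here means a weaker inhibitor, a lower number a stronger inhibitor:

compound 1, `Cc1cc(Nc2ccc(C(=O)/C=C/c3ccc(C(F)(F)F)cc3)cc2)n2nc(SCc3nc4ccccc4[nH]3)nc2n1`, gives 1850 nM
compound 2, `Cc1cc(Nc2ccc(C(=O)/C=C/c3ccc4ccccc4c3)cc2)n2nc(SCc3nc4ccccc4[nH]3)nc2n1`, gives 5 nM
compound 3, `Cc1cc(Nc2ccc(C(=O)/C=C/c3ccc(Br)cc3)cc2)n2nc(SCc3nc4ccccc4[nH]3)nc2n1`, gives 290 nM

Compound 3 stands second highest of these three numbers. Its nearest neighbour is compound 1, separated by the modest step of a 6.4-fold lower number from compound 1 to compound 3 (0.80 log units; beyond the scatter); its furthest is compound 2, separated by the large step of a 58-fold higher number from compound 2 to compound 3 (1.76 log units; beyond the scatter).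

Compound 4, `Cc1cc(Nc2ccc(C(=O)/C=C/c3ccc(Cl)cc3)cc2)n2nc(SCc3nc4ccccc4[nH]3)nc2n1`, has not yet been measured. It differs from compound 3 by chloro in place of bromo on an aromatic carbon.

Of the measured steps, only a 6.4-fold lower number from compound 1 to compound 3 (0.80 log units; beyond the scatter) changes the group on that aromatic carbon alone, and it was modest. The large steps of a 370-fold lower number from compound 1 to compound 2 (2.57 log units; beyond the scatter) and a 58-fold higher number from compound 2 to compound 3 (1.76 log units; beyond the scatter) replace the whole ring and so bear only loosely on an exchange of one halogen for another. For the measured compounds named here, no measured pair compares bromo with chloro directly.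

The step of a 1.3-fold higher number from compound 3 to compound 4 (0.12 log units; within the scatter) is therefore expected to be small, within the scatter or slightly toward a higher number. In this assay compound 4 is estimated at 380 nM, with a range from 150 nM to 1000 nM.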

Compound 4, half-maximal inhibitory concentration: 230 nM
The estimate for compound 4 lay 1.7-fold (0.22 log units) above the measured number, and the stated range covers the measured number.
By their numbers in this assay, from the lowest: compound 2; then compounds 4 and 3 (each within the scatter of the next); then compound 1.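

In this assay, the direct comparison of the two halogens on this aromatic carbon, para to a large group, gives the step of a 1.3-fold lower number from compound 3 to compound 4 (0.10 log units; within the scatter), so bromo and chloro cannot be told apart here. Chloro also sits apart from the trifluoromethyl group by the modest step of an 8.0-fold lower number from compound 1 to compound 4 (0.91 log units; beyond the scatter), while the change from naphthalen-2-yl to 4-chlorophenyl gives the large step of a 46-fold higher number from compound 2 to compound 4 (1.66 log units; beyond the scatter), so among these compounds the exchange of one halogen for the other matters far less than the replacement of the whole ring system at this end of the chain. No evidence is available to explain any of these steps.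

The compounds shown leave open whether fluoro, methoxy or an amine at this carbon would fall with the two halogens or with trifluoromethyl. They also leave open whether a quinoline ring in place of naphthalen-2-yl would give a number as low as that of compound 2.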